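Thiophen-2-yl for thiazol-2-yl on a shared nitrocatechol chalcone core

A few compounds are considered here, and "the series" means these few. Any claim that something is new, unique, unknown or untested is made for them only; others in the source may bear on it.

Of the compounds shown here, three on a shared core have been measured. In an assay on isolated protein for inhibition of Amine oxidase [flavin-containing] A (Homo sapiens), read by fluorescence (on this read-out lower numbers stand for stronger inhibition and higher numbers for weaker inhibition), compound 1 `O=C(/C=C/c1ccsc1)c1cc(O)c(O)c([N+](=O)[O-])c1` gives 41400 nM, compound 2 `O=C(/C=C/c1nccs1)c1cc(O)c(O)c([N+](=O)[O-])c1` gives 69600 nM, and compound 3 `N#Cc1cccc(/C=C/C(=O)c2cc(O)c(O)c([N+](=O)[O-])c2)c1` gives 58900 nM. The number for compound 2 is the highest of the three, yet its gaps to compound 3 and to compound 1 both lie within the usual scatter, so no order among them can be claimed. The step from compound 2 to compound 4 `O=C(/C=C/c1cccs1)c1cc(O)c(O)c([N+](=O)[O-])c1` is thiophen-2-yl in place of 1,3-thiazol-2-yl on a double-bonded chain carbon bound to a double-bonded chain carbon. Within the data shown here, only one measured step bears on it: a 1.7-fold higher number from compound 1 to compound 2 (0.23 log units; within the scatter), a change between two five-membered rings at the same place that stayed within the scatter. Compound 4 carries the same ring as compound 1, attached through a different ring carbon, and compound 1 showed the lower number of that pair. Compound 4 is therefore expected to shift by a 1.5-fold lower number from compound 2 to compound 4 (0.19 log units; within the scatter) in this assay, a move that is not expected to exceed the scatter. The estimated value of compound 4 in this assay is 45000 nM, with a range from 20000 nM to 100000 nM.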

Compound 4, half-maximal inhibitory concentration: 49900 nM
Estimate against measurement, compound 4: 1.1-fold (0.04 log units) below; the range from low to high includes it.
By their numbers in this assay, from the lowest: compounds 1, 4, 3 and 2 (each within the scatter of the next).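

In this assay, thiophen-2-yl in place of 1,3-thiazol-2-yl gives a 1.4-fold lower number from compound 2 to compound 4 (0.14 log units; within the scatter) and so stays within the scatter, which shows that going from two ring hetero atoms to one at this place does not separate the two compounds. Thiophen-2-yl in place of thiophen-3-yl gives a 1.2-fold higher number from compound 1 to compound 4 (0.08 log units; within the scatter) and also stays within the scatter, so changing the ring carbon through which the thiophene is attached does not separate them either. Nothing measured here bears on why these three five-membered aromatic rings cannot be told apart.

The compounds shown leave open whether a group of another kind on the double-bonded chain carbon, such as a piperidine ring or a phenyl ring carrying a carboxylic acid, would move the number beyond the scatter. They also leave open whether these ring changes would stay within the scatter on a core without the nitro group.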